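Hydroxyphenyl series: second 2-hydroxyphenyl swap, new place on the core

The compounds below may be only part of what the source reports. "The series", "measured", "known", "first", "only" and "open" are said of these compounds alone.

Measured so far in a functional assay on T47D cells (Homo sapiens) for cytotoxicity, read by CCK-8 assay, with a stated time of 4 days; a higher number here means a weaker inhibitor, a lower number a stronger inhibitor:
compound 1 `Oc1ccc(-c2cc(-c3ccc(O)cc3)nc(-c3ccc(O)cc3)c2)cc1`: 4270 nM
compound 2 `Oc1ccc(-c2cc(-c3ccc(O)cc3)nc(-c3ccccc3O)c2)cc1`: 50000 nM
compound 3 `Oc1ccc(-c2cc(-c3cccc(O)c3)cc(-c3cccc(O)c3)n2)cc1`: 3920 nM

Compound 1 stands second highest of the three numbers. Compound 3 sits within the scatter of it, so nothing separates them. Compound 2 stands far off, the step of a 12-fold higher number from compound 1 to compound 2 (1.07 log units; beyond the scatter) being the one large move in the set.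

Compound 4 `Oc1ccc(-c2cc(-c3ccccc3O)cc(-c3ccc(O)cc3)n2)cc1` is not yet measured. It differs from compound 1 by 2-hydroxyphenyl in place of 4-hydroxyphenyl on an aromatic carbon; the change sits on an aromatic carbon of a six-membered aromatic ring with one nitrogen, meta to two 4-hydroxyphenyl groups and opposite the ring nitrogen.

Among the measured compounds shown here, the only step that bears on it is a 12-fold higher number from compound 1 to compound 2 (1.07 log units; beyond the scatter), the same exchange of 2-hydroxyphenyl for 4-hydroxyphenyl, though at a different carbon of the shared core. For the measured compounds named here, no measured pair shows the exchange at the place it takes in compound 4, so its transfer is uncertain. Going by that one step, the number for compound 4 is expected to rise beyond the scatter in this assay, the expected step being a 4.7-fold higher number from compound 1 to compound 4 (0.67 log units; beyond the scatter), somewhat smaller than that to compound 2. Compound 4 is therefore estimated at 20000 nM, within 6000 nM to 50000 nM.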

Compound 4, half-maximal inhibitory concentration: 5350 nM
Compound 4: the middle estimate sits 3.7-fold (0.57 log units) above what was measured, outside the stated range (below it).
By their numbers in this assay, from the lowest: compounds 3, 1 and 4 (each within the scatter of the next); then compound 2.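

In this assay, 2-hydroxyphenyl in place of 4-hydroxyphenyl on the aromatic carbon opposite the ring nitrogen gives a 1.3-fold higher number from compound 1 to compound 4 (0.10 log units; within the scatter), so at this position the exchange produces no readable difference. The same exchange at a different carbon of the shared core gives a 12-fold higher number from compound 1 to compound 2 (1.07 log units; beyond the scatter), which shows that in these two pairs the outcome depends on where the exchange is made and that the large step seen earlier does not carry over to this carbon. No available evidence explains why the two positions differ.

From the compounds shown here alone, what remains open is whether the hydroxyl of the 2-hydroxyphenyl group contributes at all at the carbon opposite the ring nitrogen, a question that a plain phenyl or a methoxyphenyl group there would address. The compounds shown carry only hydroxyphenyl groups on the shared core, so they also leave open how this carbon responds to an aminophenyl group, a carboxylic acid or a longer chain.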